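The compounds below may be only part of what the source reports. "The series", "measured", "known", "first", "only" and "open" are said of these compounds alone.

Within the data shown here, compound 1 `CCN(Cc1c[nH]nn1)C(=O)COc1ccc(C)cc1` is the less active of the two compounds measured so far in an assay on HEK293 cells for agonist activity at transient receptor potential cation channel subfamily M member 8 (Homo sapiens), read by fluorescence and calcium flux, with a stated time of 15 min; on this read-out higher numbers stand for an effect only at larger amounts of compound and lower numbers for an effect already at smaller amounts: in this assay compound 1 gives 31100 nM, whereas compound 2 `Cc1ccc(OCC(=O)N(Cc2cccs2)c2ccncc2)cc1` gives 52 nM, and the gap between the two lies beyond the scatter. Compound 3 `CCN(Cc1ccc(C)s1)C(=O)COc1ccc(C)cc1` is derived from compound 1 by a single change, (5-methylthiophen-2-yl in place of 1H-1,2,3-triazol-4-yl on a saturated chain carbon bound to an amide-type nitrogen), so that the 1H-1,2,3-triazol-4-yl group with its hydrogen-bond donor is exchanged for a 5-methylthiophen-2-yl group on the saturated chain carbon bound to the amide-type nitrogen. Compound 2 also carries a thiophene-type ring on that carbon, and its value in this assay suggests such a group is compatible with strong activity. The step from compound 1 to compound 3 is therefore expected to be a large move toward lower numbers, a 16-fold lower number from compound 1 to compound 3 (1.19 log units; beyond the scatter). Compound 3 is estimated at 2000 nM, with a range of 300 nM to 15000 nM.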

Compound 3, half-maximal effective concentration: 178 nM
Compound 3: middle estimate off by 11-fold (1.05 log units), on the high side; the measured number lies below the stated range.
By their numbers in this assay, from the lowest: compound 2; then compound 3; then compound 1.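

At this position, on a saturated chain carbon bound to an amide-type nitrogen, the choice of ring has a large effect: in this assay the exchange of 1H-1,2,3-triazol-4-yl for 5-methylthiophen-2-yl gives a 170-fold lower number from compound 1 to compound 3 (2.24 log units; beyond the scatter) while the rest of the molecule stays the same. Among these compounds, the earlier pair differs in more than one place, so this is the first step that ties a shift of this size to this position alone. Nothing measured here accounts for the shift.

The change replaces the ring, removes the hydrogen-bond donor and adds a methyl all at once, so the compounds shown cannot divide the step among these differences. On these data alone, whether a phenyl or furan-2-yl group on the same carbon would give a similar step also remains open.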